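This account rests on a few compounds, and the source may have more. Where it says the series, first, only, none or still open, it means among the compounds named here.

Working notes on the series. The shared core of compound 1 `c1ccc(Cn2cc(-c3ccccc3)c3c2CCNC3)cc1` carries a phenyl on the five-membered ring; in an assay on HEK293 cells for displacement of a labelled ligand from 5-hydroxytryptamine receptor 7 (Rattus norvegicus), with a stated time of 60 min (a higher number here means a weaker inhibitor, a lower number a stronger inhibitor), compound 1 gives 220 nM. Compound 2 `FC(F)(F)Oc1ccc(-c2cn(Cc3ccccc3)c3c2CNCC3)cc1` bears a trifluoromethoxy on that phenyl, and in this assay compound 2 gives 10000 nM. Among the measured compounds shown here, compound 1 thus holds the lower of the two numbers so far, the only neighbour being compound 2 at a 45-fold higher number from compound 1 to compound 2 (1.66 log units; beyond the scatter).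

Compound 3 `Clc1ccc(-c2cn(Cc3ccccc3)c3c2CNCC3)cc1Cl` is the next member: 3,4-dichlorophenyl in place of phenyl on an aromatic carbon. For the measured compounds named here, the only measured step that bears on it is the one from compound 1 to compound 2, which placed a substituent on the same phenyl and produced a 45-fold higher number from compound 1 to compound 2 (1.66 log units; beyond the scatter), a weakening well beyond the scatter. On that single precedent a step of the same direction is expected for compound 3, though the two chlorines are a different change from a trifluoromethoxy, so the size is less certain. For compound 3 the expected step in this assay is a 6.8-fold higher number from compound 1 to compound 3 (0.83 log units; beyond the scatter). The estimate for compound 3 in this assay is 1500 nM, with a range from 400 nM to 6000 nM.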

Compound 3, inhibition constant: 4470 nM
Beside the measured number, compound 3's estimate is 3.0-fold (0.47 log units) below it; the measured number falls inside the stated range.
By their numbers in this assay, from the lowest: compound 1; then compound 3; then compound 2.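

In this assay the 3,4-dichlorophenyl change gives a 20-fold higher number from compound 1 to compound 3 (1.31 log units; beyond the scatter) and so joins the trifluoromethoxy change, which gave a 45-fold higher number from compound 1 to compound 2 (1.66 log units; beyond the scatter) at the same position. The weakening is therefore not confined to the trifluoromethoxy group: both substituted phenyls shown carry higher numbers than the unsubstituted phenyl of compound 1, and neither goes against this within these three compounds. Nothing measured here bears on the reason for either step.

From the compounds shown here alone, it remains open whether every substituent on this phenyl weakens the compound, or whether one chlorine, a methoxy or an amine on the ring would behave differently. The compounds shown also say nothing about whether a smaller group such as methyl in place of the benzyl group would alter these steps.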